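Sulfonyl-terminus variation on the amidoxime furazan series

The source may hold more compounds than are shown below. What is called first, only, known or untested is meant among the compounds shown, and "the series" means these compounds.

Measured so far:
compound 1 `NNc1nonc1/C(=N/O)Nc1ccc(F)c(Br)c1` — 556 nM
compound 2 `NS(=O)(=O)NNc1nonc1/C(=N/O)Nc1ccc(F)c(Br)c1` — 101 nM
compound 3 `O=S(=O)(CCNc1nonc1/C(=N/O)Nc1ccc(F)c(Br)c1)N1CCC1` — 143 nM

All three were run in an assay on HeLa cells for inhibition of Indoleamine 2,3-dioxygenase 1 (Homo sapiens), read by spectrophotometry, with a stated time of 24 h; a higher number here means that more compound is needed for the effect, a lower number that less compound is needed. Compound 3 gives 143 nM, the second highest of the three numbers; its nearest neighbour is compound 2, and the pair differ by a 1.4-fold higher number from compound 2 to compound 3 (0.15 log units; within the scatter), so no order between them can be stated. Its furthest neighbour is compound 1, from which it is separated by a 3.9-fold lower number from compound 1 to compound 3 (0.59 log units; beyond the scatter).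

Compound 4 `O=S(=O)(CCNc1nonc1/C(=N/O)Nc1ccc(F)c(Br)c1)NCC1CC1` has not yet been measured. It differs from compound 3 in one place: (cyclopropylmethyl)amino in place of azetidin-1-yl on a sulfonyl sulfur.

Among the compounds with values here, two measured steps touch the same region. From compound 1 to compound 2 the sulfamoyl entering on the amine nitrogen gave a 5.5-fold lower number from compound 1 to compound 2 (0.74 log units; beyond the scatter). From compound 2 to compound 3 the whole sulfonyl-bearing arm was exchanged and the result was a 1.4-fold higher number from compound 2 to compound 3 (0.15 log units; within the scatter), inside the scatter. Once a sulfonyl group is present, reshaping what sits on it has so far moved the number little, so for compound 4 a step of a 1.0-fold lower number from compound 3 to compound 4 (0.01 log units; within the scatter) is expected, not beyond the scatter in either direction. On that basis compound 4 is estimated at 140 nM, within a range of 60 nM to 350 nM.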

Compound 4, half-maximal effective concentration: 268 nM
Compound 4: the middle estimate sits 1.9-fold (0.28 log units) below what was measured; the measured number falls inside the stated range.
By their numbers in this assay, from the lowest: compounds 2, 3 and 4 (each within the scatter of the next, the first and the last beyond it); then compound 1.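

In this assay, (cyclopropylmethyl)amino in place of azetidin-1-yl on a sulfonyl sulfur gives a 1.9-fold higher number from compound 3 to compound 4 (0.27 log units; within the scatter); this is the only step shown that is confined to the group on the sulfonyl sulfur, since the earlier steps exchanged or introduced the whole sulfonyl-bearing group. Within this pair, the group on the sulfur can go from a four-membered non-aromatic ring with 1 hetero atom and 0 hydrogen-bond donors to a three-membered carbon ring with 1 hydrogen-bond donor, with a step that stays inside the scatter, although this single pair cannot separate the ring exchange from the added donor. No supporting evidence bears on this result.

Open, from the compounds shown here alone, is whether this tolerance on the sulfonyl sulfur extends to groups of a different kind, such as a morpholine, a basic amine or a carboxylic acid, or to a larger group such as a benzyl amine. Also open, going by these compounds, is how a longer chain in place of the ethyl link would behave with either of these sulfur substituents held constant.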